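The source may hold more compounds than are shown below. What is called first, only, known or untested is meant among the compounds shown, and "the series" means these compounds.

Measured compounds:
Compound 1 `Cc1ccc(C(=O)Nc2cccc(C(F)(F)F)c2)cc1-c1ccc2c(-c3ccc(C(=O)N4CCN(C)CC4)cc3)n[nH]c2c1` gives 6.5 nM in an assay on isolated protein for inhibition of Discoidin domain-containing receptor 2 (Homo sapiens), read by ELISA, with a stated time of 60 min; on this read-out higher numbers stand for weaker inhibition and lower numbers for stronger inhibition.
Compound 2 `Cc1ccc(C(=O)Nc2cccc(C(F)(F)F)c2)cc1-c1ccc2c(-c3ccc(CN4CCN(C)CC4)cc3)n[nH]c2c1` gives 6.2 nM in this assay.
Compound 3 `Cc1ccc(C(=O)Nc2cccc(C(F)(F)F)c2)cc1-c1ccc2c(-c3cn[nH]c3)n[nH]c2c1` gives 55.6 nM in this assay.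

Among the measured compounds shown here, compound 3 has the highest number of the three, so it is the weakest inhibitor here; compound 1 and compound 2 sit close together, and the only counted step, a 1.0-fold lower number from compound 1 to compound 2 (0.02 log units; within the scatter), lies within the scatter.

Compound 4 `Cc1ccc(C(=O)Nc2cccc(C(F)(F)F)c2)cc1-c1ccc2c(-c3cnn(C4CCCCO4)c3)n[nH]c2c1` is not yet measured. It differs from compound 3 by oxan-2-yl in place of hydrogen on an aromatic nitrogen. For the measured compounds named here, no measured step touches this position: the one step that exists, a 1.0-fold lower number from compound 1 to compound 2 (0.02 log units; within the scatter), changes a distant group and says nothing about what happens when the ring hydrogen on the aromatic nitrogen is replaced. Going by the values given here, the only hint comes from compound 1 and compound 2, whose larger groups on the same part of the core go with lower numbers than compound 3, but that is a different kind of change. The expectation for this assay is therefore uncertain and centred on no clear direction; a step of a 1.4-fold higher number from compound 3 to compound 4 (0.16 log units; within the scatter) is expected, with a wide range. Compound 4 is estimated at 80 nM, between 20 nM and 320 nM.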

Compound 4, half-maximal inhibitory concentration: 5.2 nM
Compound 4: the middle estimate sits 15-fold (1.19 log units) above what was measured; measured number outside the range, below it.
By their numbers in this assay, from the lowest: compounds 4, 2 and 1 (each within the scatter of the next); then compound 3.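

In this assay, among the compounds shown here, replacing hydrogen with oxan-2-yl on the aromatic nitrogen gives an 11-fold lower number from compound 3 to compound 4 (1.03 log units; beyond the scatter) and shows that this position is sensitive to substitution, which the earlier compounds could not reveal. The hydrogen on that nitrogen is therefore not needed for a low number, and a six-membered non-aromatic ring is accepted there. Nothing shown here explains why this change lowers the number so much.

Still open, on these data alone, is whether the whole oxan-2-yl ring is needed, or whether a smaller methyl group or a cyclohexyl ring without the oxygen would give a similar result on this nitrogen. A longer chain ending in an amine or a carboxylic acid at the same place also remains to be compared.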